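A few compounds are considered here, and "the series" means these few. Any claim that something is new, unique, unknown or untested is made for them only; others in the source may bear on it.

Among the compounds with values here, compound 3 `Cc1cc(NCCCc2ccccn2)n2nc(C)c(-c3ccccc3)c2n1` is the one compound of the three that yields a number in a physicochemical assay for solubility, read by HPLC, using the shake flask method, measured as kinetic solubility, with a stated time of 2 h, at pH 7.4; a higher number here means a more soluble compound, a lower number a less soluble compound: compound 3 reaches 5900 nM. Compound 1 `Cc1cc(NCc2ccccn2)n2nc(C)c(-c3ccc(F)cc3)c2n1` gives only a limit, < 5000 nM. Compound 2 `Cc1cc(NCc2ccccn2)n2ncc(-c3ccc(F)cc3)c2n1` likewise sits at a limit, < 5000 nM. The step that the two limits leave unreadable from compound 1 to compound 2 is therefore unreadable, and beyond that there is only (the limit of < 5000 nM in this assay, at which 2 of the 3 values shown sit). Compound 4 `Cc1cc(NCc2c[nH]cn2)n2nc(C)c(-c3ccccc3)c2n1` differs from compound 3 by 1H-imidazol-4-yl in place of 2-(pyridin-2-yl)ethyl on a saturated chain carbon bound to a nitrogen on an aromatic ring. Within the data shown here, no measured step touches that change, since the one readable pairing concerns a different place on the shared core and leaves no size to carry over. Compound 4 is therefore expected to move by a 2.0-fold higher number from compound 3 to compound 4 (0.31 log units; beyond the scatter), a step that the usual scatter may well cover. The estimate for compound 4 is 12000 nM, between 4000 nM and 40000 nM.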

Compound 4, solubility: 14600 nM
The estimate for compound 4 lay 1.2-fold (0.09 log units) below the measured number; the measured number falls inside the stated range.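

In this assay, within the data shown here, the change on a saturated chain carbon bound to a nitrogen on an aromatic ring gives the first step of readable size: a 2.5-fold higher number from compound 3 to compound 4 (0.39 log units; beyond the scatter). Replacing 2-(pyridin-2-yl)ethyl with 1H-imidazol-4-yl therefore moves the read-out beyond the scatter. The one earlier step cannot be read, because its two values are limits: the limit of < 5000 nM in this assay, at which 2 of the 4 values shown sit.

A single pair does not separate the effect of the 1H-imidazol-4-yl ring from that of the shorter chain. From the compounds shown here alone, how a dimethylamine or a carboxylic acid at this place would read in this assay remains open.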